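Ethoxycarbonyl for Acetyl on an Aldehyde-Bearing Coumarin Core

The source may hold more compounds than are shown below. What is called first, only, known or untested is meant among the compounds shown, and "the series" means these compounds.

Measured compounds:
compound 1, `CCC(C)c1cc(C=O)cc2cc(C(C)=O)c(=O)oc12`, 141000 nM
compound 2, `CCOC(=O)c1cc2cc(/C=C/C(=O)c3ccc(Cl)cc3)cc(C(C)CC)c2oc1=O`, 11100 nM

Two compounds carry a measured number in a functional assay on MCF7 cells (Homo sapiens) for cytotoxicity, read by sulforhodamine B assay, with a stated time of 48 h; a lower number here means a stronger inhibitor, a higher number a weaker inhibitor. Compound 1 stands at the higher of the two numbers, the weaker inhibitor; compound 2 lies below it by a gap that is beyond the usual scatter. Going by the values given here, compound 2 differs from compound 1 in more than one place, so no single step between the two can be read from their values; only the two numbers themselves are known.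

Compound 3, `CCOC(=O)c1cc2cc(C=O)cc(C(C)CC)c2oc1=O`, has not yet been measured in this assay. It differs from compound 1 in one place: ethoxy in place of methyl on a carbonyl carbon. The rest of the molecule, including the aldehyde and the branched chain on the shared core, is unchanged.

Among the compounds with values here, no measured pair shows what this single exchange does on its own. Compound 2 carries the ethoxycarbonyl group and is the stronger inhibitor, but its other difference from compound 1 leaves the contribution of the exchange undetermined. The expected step from compound 1 to compound 3 in this assay is therefore a small one, a 1.4-fold lower number from compound 1 to compound 3 (0.15 log units; within the scatter), within or near the scatter, if anything toward a lower number.

Compound 3 is expected at about 100000 nM in this assay, with a range from 30000 nM to 300000 nM.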

Compound 3, half-maximal inhibitory concentration: 113000 nM
For compound 3 the middle estimate is 1.1-fold (0.05 log units) below the measured one, and the stated range covers the measured number.
By their numbers in this assay, from the lowest: compound 2; then compounds 3 and 1 (each within the scatter of the next).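

In this assay the exchange of acetyl for ethoxycarbonyl can now be read on its own, and it gives a 1.2-fold lower number from compound 1 to compound 3 (0.10 log units; within the scatter); on this carbonyl carbon, ethoxy in place of methyl leaves the two compounds indistinguishable in this assay. The ethoxycarbonyl group alone therefore does not set compound 2 apart, since compound 3 carries the same group and gives 113000 nM while compound 2 gives 11100 nM, and these two differ only in the aldehyde of compound 3 against the chlorophenyl enone chain of compound 2. Nothing at hand offers a reason for any of these numbers.

On these data alone, it remains open whether a carboxylic acid, a primary amide or a longer alkoxy chain such as butoxy on this carbonyl carbon would give a number apart from those of compound 1 and compound 3. Also open is whether the exchange would stay as small with the chlorophenyl enone chain in place of the aldehyde, as the acetyl counterpart of compound 2 is not among the compounds shown.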